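Removing the phenyl from compound 2: expected cell tolerance

A few compounds are considered here, and "the series" means these few. Any claim that something is new, unique, unknown or untested is made for them only; others in the source may bear on it.

Compound 1 `CCCOc1ccc2ccc(=O)oc2c1CN1CCc2ccccc2C1` gives 11000 nM in an ADME assay on MT4 cells (Homo sapiens) for cytotoxicity, read by MTT assay, with a stated time of 96 h; a lower number here means that less compound is tolerated, a higher number that more compound is tolerated.
Compound 2 `CCC(=O)Oc1ccc2ccc(=O)oc2c1Cc1c(-c2ccccc2)[nH]c2ccccc12` gives > 100000 nM in this assay.

Compound 2 is known in this assay only as a limit of the assay, not as a number: compound 2 sits at the limit of > 100000 nM in this assay, at which 1 of the 2 values shown sits, so its cells tolerated the highest concentration tested. Among the compounds with values here, compound 1, with a different core, gives a measured number in this assay of 11000 nM and is the only compound of the pair with a defined value.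

Compound 3 `CCC(=O)Oc1ccc2ccc(=O)oc2c1Cc1c[nH]c2ccccc12` has not yet been measured in this assay. It differs from compound 2 in one place: hydrogen in place of phenyl on an aromatic carbon. Within the data shown here, no step between two measured compounds with this change has been recorded, so its size cannot be read from the numbers at hand. Since compound 2 stands at the limit, compound 3 is expected to stay within the scatter of that limit or to move only modestly, in either direction, and most likely to again tolerate the top concentration.

Compound 3 is therefore estimated at 100000 nM in this assay, with a range from 35000 nM to 300000 nM, which corresponds to an expected step of a number no higher from compound 2 to compound 3 (the limit leaves the size open).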

Compound 3, half-maximal cytotoxic concentration: 65000 nM
Estimate against measurement, compound 3: 1.5-fold (0.19 log units) above; the range from low to high includes it.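

In this assay, within the data shown here, hydrogen in place of phenyl on the aromatic carbon next to the ring nitrogen gives an at least 1.5-fold lower number from compound 2 to compound 3 (0.18 log units; that floor lies within the scatter), the first step at this position that can be read at all. Compound 3 gives 65000 nM, a defined number, so without the phenyl the tolerated concentration falls within the tested range and this position now has a measured reference point. Even so, the step's floor does not by itself establish a real loss of tolerance, and its true size stays open, since compound 2 is known only as a limit: the limit of > 100000 nM in this assay, at which 1 of the 3 values shown sits.

The compounds shown leave open whether a small group such as methyl, or a phenyl carrying an amine or a carboxylic acid, on that same carbon would give a value closer to that of compound 3 or a limit like that of compound 2. They also leave open whether hydrogen in place of phenyl would give a similar step if the ester on the shared core were replaced by a longer chain.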